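Hydroxamate series: amide nitrogen substituent and CAL-27 cytotoxicity

This account rests on a few compounds, and the source may have more. Where it says the series, first, only, none or still open, it means among the compounds named here.

Measured so far:
Compound 1, `CC(C)(C)NC(=O)CN(CCCCCC(=O)NO)C(=O)c1ccccc1`, 16700 nM
Compound 2, `O=C(CCCCCN(CC(=O)NC1CCCCC1)C(=O)c1ccccc1)NO`, 3800 nM
Compound 3, `CC(C)(C(=O)NC1CCCCC1)N(CCCCCC(=O)NO)C(=O)c1ccccc1`, 66900 nM

All values come from a functional assay on CAL-27 cells (Homo sapiens) for cytotoxicity, read by MTT assay, with a stated time of 72 h; a higher number here means a weaker inhibitor, a lower number a stronger inhibitor. Compound 3 gives the highest number of the three; its nearest neighbour is compound 1 and its furthest compound 2, both gaps lying beyond the scatter.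

Compound 4, `CC(C)(C)NC(=O)C(C)(C)N(CCCCCC(=O)NO)C(=O)c1ccccc1`, is not yet measured. It differs from compound 3 by tert-butyl in place of cyclohexyl on an amide-type nitrogen. The same change, at the same place, has been made once already, from compound 2 to compound 1, where it gave a 4.4-fold higher number from compound 2 to compound 1 (0.64 log units; beyond the scatter). The cores of compound 2 and compound 3 differ in more than one place, and that difference is not broken down here.

For compound 4 a step of about the same size is expected, a 3.7-fold higher number from compound 3 to compound 4 (0.57 log units; beyond the scatter), resting on the measured step from compound 2 to compound 1 and on the starting value of compound 3, 66900 nM. Compound 4 is therefore expected to fall near 250000 nM, within 80000 nM to 700000 nM. A number this high may lie past the range of the assay, so a limit rather than a value is a real possibility.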

Compound 4, half-maximal inhibitory concentration: 75800 nM
Beside the measured number, compound 4's estimate is 3.3-fold (0.52 log units) above it; the whole stated range lies above it.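

In this assay, tert-butyl in place of cyclohexyl on an amide-type nitrogen gives a 1.1-fold higher number from compound 3 to compound 4 (0.05 log units; within the scatter) and so makes no readable difference on this core. The same change therefore does not carry over at one size between the two cores: the same change on two cores in this assay, a 4.4-fold higher number (0.64 log units; beyond the scatter) from compound 2 to compound 1 and a 1.1-fold higher number (0.05 log units; within the scatter) from compound 3 to compound 4, 3.9-fold (0.59 log units) apart, beyond the scatter of two such steps. This shows that a step measured on the core of compound 2 could not be transferred unchanged to the core of compound 3, but it does not show which of the several differences between those cores separates the two steps, and one pair per core gives no rule for any further core.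

The compounds shown include no core intermediate between those two, so the part of the core difference that goes with the gap between the steps remains open. Also open, going by these compounds, is how a benzyl or cyclopentyl group on the same amide-type nitrogen would read on either core, and whether a longer chain leading to the hydroxamic acid would alter the gap.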